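The source may report more compounds than this note shows. Statements on the series, on what has been measured and on what is new or still open speak of the compounds shown alone.

Measured so far in a functional assay on MDA-MB-231 cells (Homo sapiens) for antiproliferative activity, read by sulforhodamine B assay, with a stated time of 48 h; a lower number here means a stronger inhibitor, a higher number a weaker inhibitor:
- compound 1 `COc1cc(OC)c2sc(-c3ccc(N/C=C\C(=O)c4ccc(OC)c(O)c4)c(C)c3)nc2c1`: 3100 nM
- compound 2 `COc1ccc(C(=O)/C=C\Nc2ccc(-c3nc4cc(OC)c(OC)c(OC)c4s3)cc2C)cc1O`: 12400 nM
- compound 3 `COc1cc(OC)c2sc(-c3ccc(N/C=C\C(=O)c4ccc(OC)c(O)c4)cc3)nc2c1`: 7610 nM

Compound 3 stands apart from compound 1 by a 2.5-fold higher number from compound 1 to compound 3 (0.39 log units; beyond the scatter), a step beyond the scatter, with hydrogen in place of methyl on an aromatic carbon. Compound 3 and compound 2 lie within the scatter of each other, so this assay does not separate them. Compound 1 holds the lowest number of the three.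

Next is compound 4 `COc1ccc(C(=O)/C=C\Nc2ccc(-c3nc4cc(OC)c(OC)c(OC)c4s3)cc2)cc1O`, which differs from compound 3 by methoxy in place of hydrogen on an aromatic carbon, ortho to two methoxy groups.

Among the measured compounds shown here, the one direct precedent is a 4.0-fold higher number from compound 1 to compound 2 (0.60 log units; beyond the scatter), a modest step beyond the scatter for the same exchange, made in the presence of the methyl group. For the measured compounds named here, the step of a 2.5-fold higher number from compound 1 to compound 3 (0.39 log units; beyond the scatter) shows only that the methyl group also counts. Going by these compounds, whether the methoxy step carries over unchanged to a compound without that methyl group is unknown, and a single pair is thin support.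

A step in the same direction, somewhat smaller than the precedent, is therefore expected. The expected change is a 2.9-fold higher number from compound 3 to compound 4 (0.46 log units; beyond the scatter). For compound 4 the estimated value is 22000 nM, with an expected range from 9000 nM to 50000 nM.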

Compound 4, half-maximal inhibitory concentration: 18100 nM
Estimate against measurement, compound 4: 1.2-fold (0.08 log units) above, within the range that was stated.
By their numbers in this assay, from the lowest: compound 1; then compounds 3, 2 and 4 (each within the scatter of the next, the first and the last beyond it).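

In this assay, the added methoxy, ortho to two methoxy groups, also raises the number when the methyl group is absent, with a 2.4-fold higher number from compound 3 to compound 4 (0.38 log units; beyond the scatter), so this change no longer rests on a single pair. Both pairs shown move in the same direction, and the size of the step does not separate the two cores: the same change on two cores in this assay, a 4.0-fold higher number (0.60 log units; beyond the scatter) from compound 1 to compound 2 and a 2.4-fold higher number (0.38 log units; beyond the scatter) from compound 3 to compound 4, 1.7-fold (0.23 log units) apart, within the scatter of two such steps. The exchange of hydrogen for methyl is less clear once this methoxy is present, with a 1.5-fold higher number from compound 2 to compound 4 (0.16 log units; within the scatter), so it does not separate those two compounds, and the gap between this step and the one on the core without the added methoxy also gives no evidence that the methyl effect depends on that group: the same change on two cores in this assay, a 2.5-fold higher number (0.39 log units; beyond the scatter) from compound 1 to compound 3 and a 1.5-fold higher number (0.16 log units; within the scatter) from compound 2 to compound 4, 1.7-fold (0.23 log units) apart, within the scatter of two such steps.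

Going by these compounds, only hydrogen and methoxy appear at this position, so it remains open whether a fluorine, an amine or a longer chain such as propoxy would also raise the number or would instead lower it. Also open, on these data alone, is whether the methoxy step would persist if either of the two neighbouring methoxy groups were replaced by hydrogen, and whether it would hold outside this assay.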